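Phenyl to 4-methylphenyl: notes on the series

A few compounds are considered here, and "the series" means these few. Any claim that something is new, unique, unknown or untested is made for them only; others in the source may bear on it.

Among the measured compounds shown here, in a functional assay on SGC-7901 cells (Homo sapiens) for inhibition, read by MTT assay, with a stated time of 24 h (a lower number here means a stronger inhibitor, a higher number a weaker inhibitor), compound 2 `CC1(C)[C@H]2CC[C@]1(C)N(Cc1cn(-c3ccccc3)nn1)C(=O)C2` gives 240 nM, the lowest of the two numbers so far, while compound 1 `CC1(C)[C@H]2CC[C@]1(C)N(Cc1cn(-c3ccc(F)cc3)nn1)C(=O)C2` gives 500 nM. Compound 3 `Cc1ccc(-n2cc(CN3C(=O)C[C@@H]4CC[C@@]3(C)C4(C)C)nn2)cc1` remains unmeasured. It departs from compound 2 by methyl in place of hydrogen on an aromatic carbon, which is methyl in place of hydrogen on an aromatic carbon, turning phenyl into 4-methylphenyl. For the measured compounds named here, one measured step bears on this: a 2.1-fold lower number from compound 1 to compound 2 (0.32 log units; beyond the scatter), with hydrogen in place of fluoro on an aromatic carbon, modest but beyond the scatter. Going by the values given here, no methyl compound has been measured, so this step is only a loose guide. Taking compound 1 at 500 nM as the sole measured case with a group other than hydrogen there, a modest rise is expected rather than a fall. The expected change is a 1.4-fold higher number from compound 2 to compound 3 (0.15 log units; within the scatter). For compound 3 the estimated value is 340 nM, with an expected range of 130 nM to 800 nM.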

Compound 3, half-maximal inhibitory concentration: 390 nM
Compound 3: the middle estimate sits 1.1-fold (0.06 log units) below what was measured; the range from low to high includes it.
By their numbers in this assay, from the lowest: compounds 2, 3 and 1 (each within the scatter of the next, the first and the last beyond it).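

In this assay methyl in place of hydrogen gives a 1.6-fold higher number from compound 2 to compound 3 (0.21 log units; within the scatter) and so cannot be told apart from hydrogen at this position, whereas fluoro in place of hydrogen could, read backwards from a 2.1-fold lower number from compound 1 to compound 2 (0.32 log units; beyond the scatter) on the same carbon. Methyl in place of fluoro gives a 1.3-fold lower number from compound 1 to compound 3 (0.11 log units; within the scatter) and is equally unresolved, which leaves compound 3 within the scatter of both neighbours while only compound 1 and compound 2 stand apart. The three compounds therefore show that a group here need not cost activity beyond the scatter, though nothing available accounts for the difference between fluoro and methyl.

On these data alone, what an amine, a methoxy group, a carboxylic acid or a longer chain would give at this position stays open. Also open, as far as these compounds go, is whether chloro would follow fluoro or methyl.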